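The source may report more compounds than this note shows. Statements on the series, on what has been measured and on what is new or still open speak of the compounds shown alone.

Of the compounds shown here, three have so far been measured in a physicochemical assay for lipophilicity, at pH 7.4; on this read-out lower numbers stand for lower lipophilicity and higher numbers for higher lipophilicity. Compound 1 `CCCCCCCc1c(C)nc2cc(OC)ccc2c1O` gives 3.69 in this assay. Compound 2 `CCCCCCCc1c(C)nc2ccccc2c1O` differs from compound 1 in a single place, (hydrogen in place of methoxy on an aromatic carbon), and in this assay compound 2 gives 3.39. The step this change made is a number 0.30 log units lower from compound 1 to compound 2 (within the scatter), so the two values cannot be told apart with confidence. Compound 3 `CCCCC#Cc1c(C)[nH]c2ccc(OC)cc2c1=O` is built on a different core; how the two cores differ is not broken down here. In this assay compound 3 gives 5.25, which stands beyond the scatter of both compound 1 and compound 2 and is the highest number of the three.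

Compound 4 `CCCCC#Cc1c(C)[nH]c2ccccc2c1=O` has not been measured yet. It stands to compound 3 exactly as compound 2 stands to compound 1: the change is hydrogen in place of methoxy on an aromatic carbon, the same change at the same kind of place. Resting on the step of a number 0.30 log units lower from compound 1 to compound 2 (within the scatter), the estimated step is a number 0.30 log units lower from compound 3 to compound 4 (within the scatter). Compound 4 is therefore expected to give about 4.95 in this assay, most likely between 4.55 and 5.35.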

Compound 4, distribution coefficient: 5.44
Compound 4: middle estimate off by 0.49 log units, on the low side; measured number outside the range, above it.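

Replacing methoxy with hydrogen gives, in this assay, a number 0.19 log units higher from compound 3 to compound 4 (within the scatter) on one core and a number 0.30 log units lower from compound 1 to compound 2 (within the scatter) on the other. Both steps lie within the scatter, so on neither core can this change be told apart from repeat-measurement noise, and their opposite signs cannot be read as a real reversal between the cores. Within the data shown here, this shows only that the change made no step beyond the scatter on these two cores; it does not show that the change has no effect on this read-out or that the same would hold on a further core, and nothing available here explains the result.

The compounds shown have only methoxy or hydrogen at this aromatic carbon, so a group such as an amine or a carboxylic acid there remains an open case. From the compounds shown here alone, whether either would give a step beyond the scatter, and whether that step would carry from one core to the other, also stays open.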